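Aryl swap on the ring amine: expectations for compound 4

The compounds below may be only part of what the source reports. "The series", "measured", "known", "first", "only" and "open" are said of these compounds alone.

Measured so far in a functional assay on the whole organism (strain CD1) with Mus musculus as the target, in the maximal electroshock model, with a stated time of 4 h; a lower number here means that less compound is needed, a higher number that more compound is needed for the effect:
compound 1 `CC(C)C1(C(C)C)NC(=O)N(CN2CCN(c3cccc(C(F)(F)F)c3)CC2)C1=O` — 100 mg/kg
compound 2 `O=C1NC(c2ccccc2)(c2ccccc2)C(=O)N1CN1CCN(c2cccc(Cl)c2)CC1` — 100 mg/kg
compound 3 `O=C1NC(c2ccccc2)(c2ccccc2)C(=O)N1CN1CCN(Cc2ccccc2)CC1` — 100 mg/kg

Compound 1 stands level with compounds 2 and 3; nothing separates the three beyond the scatter. Among the measured compounds shown here, the single measured step, no change at the digits printed from compound 2 to compound 3 (within the scatter), replaces one group on the amine nitrogen in a ring and leaves the minimum effective dose where it was. Compound 4 `CC(C)C1(C(C)C)NC(=O)N(CN2CCN(c3ccccc3F)CC2)C1=O` differs from compound 1 by 2-fluorophenyl in place of 3-(trifluoromethyl)phenyl on an amine nitrogen in a ring, again a change of the group on that ring nitrogen, though on a different core. With only a flat step of that kind to go by, no movement beyond the scatter is expected. Compound 4 is therefore estimated at 100 mg/kg (range 50 mg/kg to 200 mg/kg), an expected step of no change at the digits printed from compound 1 to compound 4 (within the scatter).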

Compound 4, minimum effective dose: 100 mg/kg
Estimate against measurement, compound 4: no gap at the digits printed; the range from low to high includes it.
By their numbers in this assay, from the lowest: compounds 1, 2, 3 and 4 (each within the scatter of the next).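

In this assay the swap of 3-(trifluoromethyl)phenyl for 2-fluorophenyl gives no change at the digits printed from compound 1 to compound 4 (within the scatter) and so extends what the step on the core of compound 2 showed: a change of aryl group on this amine nitrogen in a ring also leaves the dose flat on the core of compound 1. No measurement here accounts for that flatness. On these data alone, whether a methoxy group or an amine on that phenyl ring, or an acyl group directly on the ring nitrogen, would shift the minimum effective dose stays open.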